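Amine substitution on the shared core: propyl to benzyl

The source may report more compounds than this note shows. Statements on the series, on what has been measured and on what is new or still open speak of the compounds shown alone.

In a functional assay on the whole organism with Rattus norvegicus as the target, at a dose of 40 mg/kg by the intraperitoneal route (a lower number here means less inhibition, a higher number more inhibition at the dose given (going by the name of the read-out)), the measured compounds read as follows.
Compound 1 `Cc1nc2c(OCc3ccccc3)cccn2c1N` gives 99%.
Compound 2 `CNc1c(C)nc2c(OCc3ccccc3)cccn12` gives 55%.
Compound 3 `CCCNc1c(C)nc2c(OCc3ccccc3)cccn12` gives 99%.

Compound 3 stands level with compound 1 at the digits printed, and together they hold the highest number of the three; the steps into compound 3 are a number 44 percentage points higher from compound 2 to compound 3 (beyond the scatter) and no change at the digits printed from compound 1 to compound 3 (within the scatter). The step of a number 44 percentage points lower from compound 1 to compound 2 (beyond the scatter) shows the methyl on the ring nitrogen as the only substituent to lower the read-out.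

Compound 4 `Cc1nc2c(OCc3ccccc3)cccn2c1NCc1ccccc1` differs from compound 3 by phenyl in place of ethyl on a saturated chain carbon bound to a nitrogen on an aromatic ring. The step that bears on it most is a number 44 percentage points higher from compound 2 to compound 3 (beyond the scatter), a large rise on the same saturated chain carbon bound to the nitrogen on the aromatic ring; the step of no change at the digits printed from compound 1 to compound 3 (within the scatter) shows propyl and hydrogen level. Compound 3 already sits at the top of the scale, so for compound 4 the expected step is a number 4 percentage points lower from compound 3 to compound 4 (within the scatter), none beyond the scatter.

Compound 4 is estimated at 95%, with a range of 70% to 100%.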

Compound 4, a percentage reported as inhibition, in the whole organism at one dose (the size of the read-out at that dose, not a potency): 48%
For compound 4 the middle estimate is 47 percentage points above the measured one; the measured number lies below the stated range.
By their numbers in this assay, from the lowest: compounds 4 and 2 (each within the scatter of the next); then compounds 1 and 3 (each within the scatter of the next).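

On this nitrogen, the level held by propyl does not carry over to benzyl in this assay: the change gives a number 51 percentage points lower from compound 3 to compound 4 (beyond the scatter) and, set against the free amine, a number 51 percentage points lower from compound 1 to compound 4 (beyond the scatter) as well. Benzyl and methyl read alike, with a number 7 percentage points lower from compound 2 to compound 4 (within the scatter), so among the three substituents shown on this nitrogen only propyl stays level with hydrogen, and the read-out does not follow the number of carbons in the substituent. Nothing on hand accounts for these steps.

Still open, from the compounds shown here alone, is whether the loss belongs to the aromatic ring or to benzyl as a whole, a question a cyclohexylmethyl group on the same nitrogen would address. A butyl group or a longer chain would show how far the level seen with propyl extends.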